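The compounds below may be only part of what the source reports. "The series", "measured", "known", "first", "only" and "open" are said of these compounds alone.

In a functional assay on DLD-1 cells (Homo sapiens) for cytotoxicity, with a stated time of 48 h (a higher number here means a weaker inhibitor, a lower number a stronger inhibitor), compound 1 `CCCCCOc1ccc2oc(/C=C/[S+](C)[O-])cc(=O)c2c1` gives 6600 nM and compound 2 `C[S+]([O-])/C=C/c1cc(=O)c2cc(Cl)ccc2o1` gives 6500 nM as its read-out. Compound 3 `CC(C)C(=O)Oc1ccc2oc(/C=C/[S+](C)[O-])cc(=O)c2c1` gives 9100 nM and so stands within the scatter of both. Compound 4 `COc1ccc2oc(/C=C/[S+](C)[O-])cc(=O)c2c1` has not yet been measured. It carries methyl in place of isopropylcarbonyl on an oxygen on an aromatic ring. The closest measured change swaps pentyl for isopropylcarbonyl on that oxygen and gives a 1.4-fold higher number from compound 1 to compound 3 (0.14 log units; within the scatter) as its result. The other two steps (a 1.0-fold lower number from compound 1 to compound 2 (0.01 log units; within the scatter) and a 1.4-fold higher number from compound 2 to compound 3 (0.15 log units; within the scatter)) also stay within the scatter. No step beyond the scatter is therefore expected in this assay for this change. The expected step is a 1.2-fold lower number from compound 3 to compound 4 (0.08 log units; within the scatter) and no larger. For compound 4 the estimate is 7500 nM (expected range 3500 nM to 16000 nM).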

Compound 4, half-maximal inhibitory concentration: 5700 nM
Compound 4: the middle estimate sits 1.3-fold (0.12 log units) above what was measured, within the range that was stated.
By their numbers in this assay, from the lowest: compounds 4, 2, 1 and 3 (each within the scatter of the next).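

In this assay, methyl in place of isopropylcarbonyl on the oxygen on an aromatic ring gives a 1.6-fold lower number from compound 3 to compound 4 (0.20 log units; within the scatter), so losing the carbonyl here moves the number no more than the scatter allows. Methoxy also matches the longer pentyloxy, with a 1.2-fold lower number from compound 1 to compound 4 (0.06 log units; within the scatter), and chloro, with a 1.1-fold lower number from compound 2 to compound 4 (0.06 log units; within the scatter), so all four groups at this place stay within the scatter of one another. Nothing available explains this flat picture. As far as these compounds go, whether an amine, a carboxylic acid or a far longer chain here would shift the number beyond the scatter remains open.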